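A few compounds are considered here, and "the series" means these few. Any claim that something is new, unique, unknown or untested is made for them only; others in the source may bear on it.

Of the compounds shown here, three have been measured in a functional assay on MCF7 cells (Homo sapiens) for cytotoxicity, read by sulforhodamine B assay; a higher number here means a weaker inhibitor, a lower number a stronger inhibitor. Compound 1 `C=C1[C@@H](C/C=C2/C(=O)OC[C@H]2OC(C)=O)[C@]2(C)CC[C@@H](OC(C)=O)[C@@](C)(CO[Si](C)(C)C(C)(C)C)[C@H]2C[C@@H]1O` gives 6960 nM and compound 3 `C=C1CC[C@@H]2[C@](C)(CO[Si](C)(C)C(C)(C)C)[C@H](OC(C)=O)CC[C@@]2(C)[C@@H]1C/C=C1/C(=O)OC[C@H]1OC(C)=O` gives 4840 nM, while compound 2 `C=C1[C@@H](OC(C)=O)C[C@@H]2[C@](C)(COC=O)[C@H](OC(C)=O)CC[C@@]2(C)[C@@H]1C[C@@H](Nc1ccccc1C(=O)O)C1=CCOC1=O` gives 30800 nM, the highest of the three numbers and beyond the scatter from both of the others. Among the measured compounds shown here, the only measured step, a 1.4-fold lower number from compound 1 to compound 3 (0.16 log units; within the scatter), concerns a change on the shared core and is within the scatter. Compound 4 `C=C1[C@@H](OC(C)=O)C[C@@H]2[C@](C)(COC=O)[C@H](OC(C)=O)CC[C@@]2(C)[C@@H]1C[C@@H](Nc1ccccc1F)C1=CCOC1=O` differs from compound 2 by fluoro in place of carboxy on an aromatic carbon. For the measured compounds named here, no measured step touches this part of the molecule, and the single step available gives no guidance on size or direction. The step expected is therefore a 1.4-fold lower number from compound 2 to compound 4 (0.15 log units; within the scatter), nothing beyond the scatter. Compound 4 is estimated at about 22000 nM, with a range from 6000 nM to 80000 nM.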

Compound 4, half-maximal inhibitory concentration: 16400 nM
Estimate against measurement, compound 4: 1.3-fold (0.13 log units) above; low and high end bracket the measured number.
By their numbers in this assay, from the lowest: compounds 3 and 1 (each within the scatter of the next); then compounds 4 and 2 (each within the scatter of the next).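

In this assay, among the compounds shown here, fluoro in place of carboxy on the aromatic ring gives a 1.9-fold lower number from compound 2 to compound 4 (0.27 log units; within the scatter), the first measured change at this part of the molecule. Here, a group of three heavy atoms with a hydrogen-bond donor gives way to a single fluorine atom, and the number does not move beyond the scatter. No measurement at hand bears on the reason for this result. From the compounds shown here alone, what an amine or a methyl ester on this aromatic carbon would give remains open, as does the reading for plain hydrogen there.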